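This account rests on a few compounds, and the source may have more. Where it says the series, first, only, none or still open, it means among the compounds named here.

Measured in a functional assay on NCI-H460 cells (Homo sapiens) for cytotoxicity, read by MTT assay, with a stated time of 72 h; a lower number here means a stronger inhibitor, a higher number a weaker inhibitor:

- compound 1 `CC(C)c1[nH]cnc1/C=c1\[nH]c(=O)/c(=C/c2cccc(C(=O)c3ccc(F)cc3)c2)[nH]c1=O` gives 3.2 nM
- compound 2 `Cc1[nH]cnc1/C=c1\[nH]c(=O)/c(=C/c2cccc(C(=O)c3ccc(F)cc3)c2)[nH]c1=O` gives 15.9 nM
- compound 3 `Cc1ccc(/C=c2\[nH]c(=O)/c(=C/c3cccc(C(=O)c4ccc(F)cc4)c3)[nH]c2=O)o1` gives 5.3 nM

Compound 3 sits level with compound 1, as a 1.7-fold higher number from compound 1 to compound 3 (0.22 log units; within the scatter) shows, and apart from compound 2, as a 3.0-fold lower number from compound 2 to compound 3 (0.48 log units; beyond the scatter) shows. Compound 4 `COCc1ccc(/C=c2\[nH]c(=O)/c(=C/c3cccc(C(=O)c4ccc(F)cc4)c3)[nH]c2=O)o1` turns the 5-methylfuran-2-yl group of compound 3 into 5-(methoxymethyl)furan-2-yl, with methoxy in place of hydrogen on a saturated chain carbon bound to an aromatic carbon. Within the data shown here, no measured step makes this change. The closest guide is the exchange of isopropyl for methyl, a 5.0-fold higher number from compound 1 to compound 2 (0.70 log units; beyond the scatter), a modest move, but one made on the imidazole rather than the furan. It suggests that a small group on this ring can shift the number only modestly, and it gives no direction for methoxy. The expected change is therefore small, at most slightly upward, and the estimated step is a 1.3-fold higher number from compound 3 to compound 4 (0.12 log units; within the scatter), which would stay within the scatter. For compound 4 the estimated value is 7 nM, with an expected range from 2.5 nM to 20 nM.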

Compound 4, half-maximal inhibitory concentration: 2.9 nM
Estimate against measurement, compound 4: 2.4-fold (0.38 log units) above; the range from low to high includes it.
By their numbers in this assay, from the lowest: compounds 4, 1 and 3 (each within the scatter of the next); then compound 2.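

In this assay, adding methoxy on a saturated chain carbon bound to an aromatic carbon leaves the number level (a 1.8-fold lower number from compound 3 to compound 4 (0.26 log units; within the scatter)), so this position accepts methoxymethyl as well as methyl without a change beyond the scatter. The 5-(methoxymethyl)furan-2-yl group also sits level with the 5-isopropyl-1H-imidazol-4-yl group (a 1.1-fold lower number from compound 1 to compound 4 (0.04 log units; within the scatter)) and apart from the 5-methyl-1H-imidazol-4-yl group (a 5.5-fold lower number from compound 2 to compound 4 (0.74 log units; beyond the scatter)), which leaves compound 2 as the only one of the four set apart from all the others. Nothing available gives a measured reason for these results.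

The compounds shown leave open whether an amine, a carboxylic acid or a longer chain such as ethoxymethyl in place of this methoxymethyl would hold the number at this level. They also leave open whether 5-(methoxymethyl)-1H-imidazol-4-yl would behave as the furan group does.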